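Swapping the meta substituent on the urea's aryl ring

This account rests on a few compounds, and the source may have more. Where it says the series, first, only, none or still open, it means among the compounds named here.

In a functional assay for antagonist activity at melanin-concentrating hormone receptor 1 (Homo sapiens) (on this read-out higher numbers stand for weaker inhibition and lower numbers for stronger inhibition), the measured compounds give:
compound 1, `CC(C)N(CCN(C(=O)Nc1cccc([N+](=O)[O-])c1)C1CC[C@]2(c3cccc(C#N)c3)CC2C1)C(C)C`: 2.7 nM
compound 2, `CC(C)N(CCN(C(=O)Nc1cccc(Br)c1)C1CC[C@]2(c3cccc(C#N)c3)CC2C1)C(C)C`: 5.7 nM
compound 3, `CC(C)N(CCN(C(=O)Nc1cccc(C#N)c1)C1CC[C@]2(c3cccc(C#N)c3)CC2C1)C(C)C`: 7.6 nM

Compound 3 shows the highest number of the three, though the nearer of its two steps, a 1.3-fold higher number from compound 2 to compound 3 (0.12 log units; within the scatter), lies within the scatter. Against compound 1 the gap is larger: a 2.8-fold higher number from compound 1 to compound 3 (0.45 log units; beyond the scatter), alongside a 2.1-fold higher number from compound 1 to compound 2 (0.32 log units; beyond the scatter).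

Compound 4, `CC(C)N(CCN(C(=O)Nc1cc(F)cc(F)c1)C1CC[C@]2(c3cccc(C#N)c3)CC2C1)C(C)C`, differs from compound 3 by 3,5-difluorophenyl in place of 3-cyanophenyl on an amide-type nitrogen. Among the measured compounds shown here, no measured step makes this exact exchange; the three steps above each replace one aryl substituent with another and stay modest or within the scatter. By that pattern, the expected step of a 1.1-fold higher number from compound 3 to compound 4 (0.02 log units; within the scatter) is small, with no clear direction. Compound 4 is therefore estimated at 8 nM in this assay, expected between 3 nM and 25 nM.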

Compound 4, inhibition constant: 4.5 nM
For compound 4 the middle estimate is 1.8-fold (0.25 log units) above the measured one; low and high end bracket the measured number.
By their numbers in this assay, from the lowest: compounds 1, 4, 2 and 3 (each within the scatter of the next, the first and the last beyond it).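

Replacing the single nitro, bromo or cyano group with the 3,5-difluorophenyl ring on the amide-type nitrogen stays within the scatter of all three earlier compounds (a 1.7-fold lower number from compound 3 to compound 4 (0.23 log units; within the scatter); a 1.3-fold lower number from compound 2 to compound 4 (0.10 log units; within the scatter); a 1.7-fold higher number from compound 1 to compound 4 (0.22 log units; within the scatter)). Compound 4 therefore keeps the activity of the series with a group counted as having no hydrogen-bond acceptor, although compound 1 and compound 3 differ beyond the scatter. No supporting measurement explains this result.

Still open, from the compounds shown here alone, is whether this ring needs any substituent, as a plain phenyl group would show. A 3-methoxyphenyl or 3-aminophenyl group could also test how broadly this position tolerates change.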